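The compounds below may be only part of what the source reports. "The series", "measured", "known", "first", "only" and "open" are said of these compounds alone.

Measured in a functional assay on OVCAR-3 cells (Homo sapiens) for inhibition, read by MTT assay, with a stated time of 24 h; on this read-out lower numbers stand for stronger inhibition and higher numbers for weaker inhibition:
- compound 1 `CC1(C)[C@H]2CC[C@]1(C)N(Cc1cn(-c3ccccc3C#N)nn1)C(=O)C2`: 110 nM
- compound 2 `CC1(C)[C@H]2CC[C@]1(C)N(Cc1cn(-c3cccc(Br)c3)nn1)C(=O)C2`: 30 nM

Of these two numbers, the lower belongs to compound 2, at 30 nM, and it therefore stands as the stronger inhibitor in this assay. The next step leads to compound 3 `CC1(C)[C@H]2CC[C@]1(C)N(Cc1cn(-c3ccc(Cl)cc3)nn1)C(=O)C2`, which keeps the shared core and has 4-chlorophenyl in place of 3-bromophenyl on an aromatic nitrogen.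

Going by the values given here, only one measured step bears on this change. It altered the group on the same aromatic nitrogen, with 3-bromophenyl in place of 2-cyanophenyl, and gave a 3.7-fold lower number from compound 1 to compound 2 (0.56 log units; beyond the scatter), a modest step beyond the scatter. Among the compounds with values here, no compound with 4-chlorophenyl has been measured yet, so the direction of the new step is not settled by the data. Since the group that enters differs less from the one that leaves than in the earlier step, a step no larger than a 3.7-fold lower number from compound 1 to compound 2 (0.56 log units; beyond the scatter) is expected, leaning slightly towards a higher number. The expected change is a 1.5-fold higher number from compound 2 to compound 3 (0.18 log units; within the scatter).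

For compound 3 the estimated value is 45 nM, with an expected range from 15 nM to 130 nM.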

Compound 3, half-maximal inhibitory concentration: 160 nM
The estimate for compound 3 lay 3.6-fold (0.55 log units) below the measured number; measured number outside the range, above it.
By their numbers in this assay, from the lowest: compound 2; then compounds 1 and 3 (each within the scatter of the next).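

In this assay, the position on the aromatic nitrogen proved sensitive even to a swap that leaves the counts unchanged: 3-bromophenyl and 4-chlorophenyl have the same number of heavy atoms, the same carbon-only aromatic ring and no hydrogen-bond donors or acceptors, yet the data show a 5.3-fold higher number from compound 2 to compound 3 (0.73 log units; beyond the scatter) for this change. The earlier compounds had not shown that 4-chlorophenyl and 2-cyanophenyl could not be told apart here, but a 1.5-fold higher number from compound 1 to compound 3 (0.16 log units; within the scatter) places these two groups together, so that compound 2 stands apart from both compound 1 and compound 3 by steps beyond the scatter. No measurement at hand explains why 3-bromophenyl differs from the other two groups.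

The compounds shown leave open whether the step follows the change of halogen or its place on the phenyl ring, and chlorine at the place that bromine holds in 3-bromophenyl would separate the two. They also leave open how this assay would read a phenyl ring carrying an amine or a carboxylic acid on the same aromatic nitrogen.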